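The compounds below may be only part of what the source reports. "The series", "measured", "known", "first", "only" and "open" are said of these compounds alone.

The study works on one shared core, the structure of which stands beside compound 1 `O=C1/C(=C/c2cccnc2)CN(S(=O)(=O)c2ccc(Br)cc2)C/C1=C\c1ccccc1F`, varied at two places. In a functional assay on SMMC-7721 cells (Homo sapiens) for cytotoxicity, read by MTT assay, with a stated time of 24 h (a higher number here means a weaker inhibitor, a lower number a stronger inhibitor), compound 1 gives 9100 nM. Compound 2 `N#Cc1ccc(S(=O)(=O)N2C/C(=C\c3cccnc3)C(=O)/C(=C/c3ccccc3F)C2)cc1` differs from compound 1 by cyano in place of bromo on an aromatic carbon, and in this assay compound 2 gives 15400 nM; the step is a 1.7-fold higher number from compound 1 to compound 2 (0.23 log units; within the scatter). Compound 3 `O=C1/C(=C/c2ccncc2)CN(S(=O)(=O)c2ccc(Br)cc2)C/C1=C\c1ccccc1F` keeps the sulfonyl group of compound 1 but carries a changed core; the difference between the two cores is pyridin-4-yl in place of pyridin-3-yl on a double-bonded chain carbon bound to a double-bonded ring carbon. In this assay compound 3 gives 12600 nM, a step of a 1.4-fold higher number from compound 1 to compound 3 (0.14 log units; within the scatter). Within the data shown here, compounds 2 and 3 differ at both places at once, so no single step is counted between them; their two values lie close together.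

Compound 4 `N#Cc1ccc(S(=O)(=O)N2C/C(=C\c3ccncc3)C(=O)/C(=C/c3ccccc3F)C2)cc1` has not yet been measured in this assay. It differs from compound 3 by cyano in place of bromo on an aromatic carbon. Among the measured compounds shown here, this is the same change as the one made from compound 1 to compound 2, since the two places read the same word for word, and the change can therefore be read as a second application of cyano in place of bromo on an aromatic carbon.

Resting on the step of a 1.7-fold higher number from compound 1 to compound 2 (0.23 log units; within the scatter), compound 4 is expected to show a step of a 1.5-fold higher number from compound 3 to compound 4 (0.18 log units; within the scatter) from compound 3 in this assay. Compound 4 is accordingly estimated at 19000 nM, with a range from 9500 nM to 38000 nM.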

Compound 4, half-maximal inhibitory concentration: 16200 nM
For compound 4 the middle estimate is 1.2-fold (0.07 log units) above the measured one; the range from low to high includes it.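

In this assay, cyano in place of bromo gives a 1.3-fold higher number from compound 3 to compound 4 (0.11 log units; within the scatter), and this step agrees with the one seen earlier on the other core: the same change on two cores in this assay, a 1.7-fold higher number (0.23 log units; within the scatter) from compound 1 to compound 2 and a 1.3-fold higher number (0.11 log units; within the scatter) from compound 3 to compound 4, 1.3-fold (0.12 log units) apart, within the scatter of two such steps. Pyridin-4-yl in place of pyridin-3-yl gives a 1.1-fold higher number from compound 2 to compound 4 (0.02 log units; within the scatter), and this change also reads alike whichever group the sulfonyl carries: the same change on two cores in this assay, a 1.4-fold higher number (0.14 log units; within the scatter) from compound 1 to compound 3 and a 1.1-fold higher number (0.02 log units; within the scatter) from compound 2 to compound 4, 1.3-fold (0.12 log units) apart, within the scatter of two such steps. Both changes therefore carry from one core to the other in this series only in a limited sense: on each core the step stays within the scatter, so the agreement shows that neither change moves the number measurably here, but it does not show that either change has a real effect, or that a larger step would carry over in the same way.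

The compounds shown leave open what other groups would do on that aromatic carbon in place of bromo or cyano, such as an amine or a carboxylic acid, and what a pyridin-2-yl group would do in place of the two pyridinyl groups. They also leave open whether these steps would hold on a core with a different group in place of the 2-fluorophenyl ring.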